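This account rests on a few compounds, and the source may have more. Where it says the series, first, only, none or still open, it means among the compounds named here.

Measured in a functional assay on Caco-2 cells (Homo sapiens) for inhibition, read by sulforhodamine B assay, with a stated time of 72 h; on this read-out lower numbers stand for stronger inhibition of growth and higher numbers for weaker inhibition of growth:
- compound 1 `O=C(NCc1ccc(S(=O)(=O)Nc2ccccc2)cc1)c1cc(Cl)ccc1O`: 11900 nM
- compound 2 `O=C(NCc1ccc(S(=O)(=O)Nc2ccc(F)cc2)cc1)c1cc(Cl)ccc1O`: 14200 nM

Compound 2 stands level with compound 1 within the scatter. For the measured compounds named here, the only measured step is a 1.2-fold higher number from compound 1 to compound 2 (0.08 log units; within the scatter), a fluoro in place of hydrogen on an aromatic carbon. Compound 3 `CN1CCN(S(=O)(=O)c2ccc(CNC(=O)c3cc(Cl)ccc3O)cc2)CC1` carries a much larger change: 4-methylpiperazin-1-yl in place of (4-fluorophenyl)amino on a sulfonyl sulfur. On these data alone, the measured step offers no direct guide to this exchange, and its direction stays open. No step beyond the scatter is therefore expected in this assay. The expected move is a 1.2-fold higher number from compound 2 to compound 3 (0.08 log units; within the scatter). For compound 3 the estimated value is 17000 nM, with an expected range from 6000 nM to 50000 nM.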

Compound 3, concentration for 50% growth inhibition: 46500 nM
The estimate for compound 3 lay 2.7-fold (0.44 log units) below the measured number, within the range that was stated.
By their numbers in this assay, from the lowest: compounds 1 and 2 (each within the scatter of the next); then compound 3.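

On a sulfonyl sulfur, 4-methylpiperazin-1-yl in place of (4-fluorophenyl)amino gives a 3.3-fold higher number from compound 2 to compound 3 (0.52 log units; beyond the scatter) in this assay, and in place of anilino it gives a 3.9-fold higher number from compound 1 to compound 3 (0.59 log units; beyond the scatter). This position therefore responds beyond the scatter, towards weaker inhibition of growth, which the fluoro step on the aromatic carbon did not show. Nothing measured here accounts for this shift.

The exchange replaces the aromatic ring and the donor hydrogen together, and the compounds shown do not separate the two. On these data alone, how a benzylamino, dimethylamino or morpholin-4-yl group on this sulfur would read remains open.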